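A Shorter Chain End on a Weakly Cytotoxic Fragment

The source may report more compounds than this note shows. Statements on the series, on what has been measured and on what is new or still open speak of the compounds shown alone.

Of the compounds shown here, two have been tested in an ADME assay on L6 cells (Rattus norvegicus) for cytotoxicity, read by fluorescence, with a stated time of 72 h; a lower number here means a stronger inhibitor, a higher number a weaker inhibitor. The larger one, compound 1 `CC(C)(C)n1nnnc1C(NCCCCNc1ccnc2cc(Cl)ccc12)c1ccc(CO[C@@H]2COc3nc([N+](=O)[O-])cn3C2)cc1`, carries a long side chain on a shared core, and in this assay compound 1 gives 29300 nM. For the measured compounds named here, the smaller one, compound 2 `OCCCNc1ccnc2cc(Cl)ccc12`, keeps only that core with a short hydroxylated chain, and compound 2 gives 178000 nM, the highest number of the two and a gap to compound 1 that lies beyond the usual scatter of repeated measurements.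

The next compound, compound 3 `NCCNc1ccnc2cc(Cl)ccc12`, differs from compound 2 in one place: amino in place of hydroxymethyl on a saturated chain carbon, two bonds along the chain from a nitrogen on an aromatic ring. Going by the values given here, no pair of measured compounds shows the effect of such a small change on this assay, so the only guide is that both compounds are small fragments of compound 1 and weak inhibitors. The change is therefore expected to make little difference, with a step from compound 2 to compound 3 of about a 1.2-fold lower number from compound 2 to compound 3 (0.07 log units; within the scatter), not beyond the scatter. On that basis, compound 3 is estimated to give 150000 nM, within a range from 60000 nM to 400000 nM.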

Compound 3, half-maximal inhibitory concentration: 21200 nM
For compound 3 the middle estimate is 7.1-fold (0.85 log units) above the measured one; measured number below the stated range.
By their numbers in this assay, from the lowest: compounds 3 and 1 (each within the scatter of the next); then compound 2.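

In this assay, putting amino in place of hydroxymethyl is far from a neutral swap: the change gives an 8.4-fold lower number from compound 2 to compound 3 (0.92 log units; beyond the scatter), so a small fragment of this kind responds clearly to what is carried on a saturated chain carbon, two bonds along the chain from a nitrogen on an aromatic ring. For the compounds shown here, the earlier compounds could not show this, as compound 1 and compound 2 differ in more than one place, and this step is the first to isolate a single change. The counts of hydrogen-bond donors and acceptors are the same in the group that leaves and the group that enters, so those counts alone do not follow the step, and no measurement at hand explains it.

The change also does two things at once, since it can be read as 3-hydroxypropyl to 2-aminoethyl: the end group differs and the chain is shorter. The compounds shown leave open which of these carries the step, and a 3-aminopropyl chain on the same core would be the direct way to tell the amine from the chain length.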